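Methoxy to isopropoxy on the fluorophenyl ring of compound 1

The source may report more compounds than this note shows. Statements on the series, on what has been measured and on what is new or still open speak of the compounds shown alone.

Measured so far in an assay on BAF cells for inhibition of ribosomal protein S6 kinase alpha-2 (Mus musculus); on this read-out higher numbers stand for weaker inhibition and lower numbers for stronger inhibition:
compound 1 `COc1cc(Nc2nc3cccc(-c4c(F)cccc4OC)c3o2)cc(OC)c1OC` gives 2600 nM
compound 2 `COc1cc(Nc2nc3cccc(-c4c(F)cccc4OC)c3o2)cc(OC)c1` gives 17200 nM
compound 3 `COc1ccc(Nc2nc3cccc(-c4c(F)cccc4OC)c3o2)cc1O[C@H]1CCNC1` gives 6300 nM

Compound 1 holds the lowest number of the three; compound 3 is nearest and compound 2 furthest. Among the measured compounds shown here, the one single-point step, a 6.6-fold higher number from compound 1 to compound 2 (0.82 log units; beyond the scatter), comes from removing a methoxy on the aniline side of the core. Compound 3 differs from compound 1 in more than one place, so its value is only a reference point.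

Compound 4 `COc1cc(Nc2nc3cccc(-c4c(F)cccc4OC(C)C)c3o2)cc(OC)c1OC` changes the other side: isopropyl in place of methyl on an oxygen on an aromatic ring. For the measured compounds named here, no measured step touches this oxygen, so nothing here sizes the effect. The expectation is a small weakening, a 1.5-fold higher number from compound 1 to compound 4 (0.19 log units; within the scatter), with wide uncertainty. Compound 4 is thus estimated at 4000 nM, in the range 1500 nM to 11000 nM in this assay.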

Compound 4, half-maximal inhibitory concentration: > 20000 nM
Compound 4: only a limit was reported; the forecaster's own chance of this, stated with the estimate: 5%; at least 5.0-fold (0.69 log units) between middle value and limit.
By their numbers in this assay, from the lowest: compound 1; then compound 3; then compound 2. At a limit, above all of these: compound 4.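

Methoxy to isopropoxy on an oxygen on an aromatic ring is the first change at this oxygen, and it does not leave the read-out in this assay unchanged: an at least 7.6-fold higher number from compound 1 to compound 4 (0.88 log units; beyond the scatter). The effect is therefore not confined to the aniline side of the core. Compound 4 stands at a limit of the assay, so the step has a lower bound only: the limit of > 20000 nM in this assay, at which 1 of the 4 values shown sits.

From the compounds shown here alone, the true size of the step remains open. So does whether ethoxy or hydroxy on this oxygen would keep the number of compound 1 in this assay.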